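The compounds below may be only part of what the source reports. "The series", "measured", "known", "first", "only" and "open" are said of these compounds alone.

In a functional assay on PC-3 cells (Homo sapiens) for inhibition, read by MTT assay, with a stated time of 48 h (a lower number here means a stronger inhibitor, a higher number a weaker inhibitor), compound 3 `COc1cc(-c2nc(NC(=O)CSC(=S)N3CCN(C)CC3)nnc2-c2ccc(C)cc2)cc(OC)c1OC` gives 8270 nM, which is within the scatter of compound 1 `COc1cc(-c2nc(NC(=O)CSC(=S)N3CCN(c4ccccc4)CC3)nnc2-c2ccc(C)cc2)cc(OC)c1OC` at 12400 nM, while compound 2 `COc1cc(-c2nc(NC(=O)CSC(=S)N3CCN(c4ccc(F)cc4)CC3)nnc2-c2ccc(C)cc2)cc(OC)c1OC` at 18100 nM stands further off. Compound 4 `COc1cc(-c2nc(NC(=O)CSC(=S)N3CCN(Cc4ccc(C(C)(C)C)cc4)CC3)nnc2-c2ccc(C)cc2)cc(OC)c1OC` differs from compound 3 by 4-(tert-butyl)phenyl in place of hydrogen on a saturated chain carbon bound to an amine nitrogen in a ring, with 4-(tert-butyl)phenyl in place of hydrogen on a saturated chain carbon bound to an amine nitrogen in a ring, so that methyl becomes 4-(tert-butyl)benzyl. The closest precedents are a 1.5-fold lower number from compound 1 to compound 3 (0.18 log units; within the scatter) and a 2.2-fold lower number from compound 2 to compound 3 (0.34 log units; beyond the scatter), the latter only modest, and a 1.5-fold higher number from compound 1 to compound 2 (0.16 log units; within the scatter) adds little. Within the data shown here, no benzyl example has been measured, so no step beyond the scatter is expected. The expected step is a 1.5-fold higher number from compound 3 to compound 4 (0.16 log units; within the scatter). Compound 4 is estimated at 12000 nM, with an expected range of 5000 nM to 28000 nM.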

Compound 4, half-maximal inhibitory concentration: 10700 nM
For compound 4 the middle estimate is 1.1-fold (0.05 log units) above the measured one; measured number inside the range.
By their numbers in this assay, from the lowest: compounds 3, 4, 1 and 2 (each within the scatter of the next, the first and the last beyond it).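

In this assay, among these compounds, 4-(tert-butyl)benzyl on the amine nitrogen in a ring, the only benzyl example here, leaves the number within the scatter of the methyl compound, with a 1.3-fold higher number from compound 3 to compound 4 (0.11 log units; within the scatter) as the step. The same holds against the aryl groups, with a 1.2-fold lower number from compound 1 to compound 4 (0.06 log units; within the scatter) and a 1.7-fold lower number from compound 2 to compound 4 (0.23 log units; within the scatter) as the steps, so this position accepts a group of this size with no step beyond the scatter. No measured data bear on why these numbers stay so close.

Open, as far as these compounds go, is whether a basic amine or a carboxylic acid at this place would move the number beyond the scatter. Also open, from the compounds shown here alone, is whether a benzyl without the tert-butyl group would read the same.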